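The compounds below may be only part of what the source reports. "The series", "measured", "known", "first", "only" and "open" are said of these compounds alone.

Compound 1 `N#Cc1ccc(Cc2cnc(CCc3ccc(-c4ccccc4C(=O)O)cc3)[nH]2)cc1`: 5890 nM
Compound 2 `O=C(O)c1ccccc1-c1ccc(CCc2ncc(CCC3CCCCC3)[nH]2)cc1`: 642 nM
Compound 3 `O=C(O)c1ccccc1-c1ccc(CCc2ncc(CC3CC3)[nH]2)cc1`: 1000 nM

In an in vitro functional assay on cells for agonist activity at Bombesin receptor subtype-3 (Homo sapiens), read by luminescence and calcium flux (on this read-out higher numbers stand for an effect only at larger amounts of compound and lower numbers for an effect already at smaller amounts), compound 3 gives 1000 nM, the second highest of the three numbers. Its step to compound 2, a 1.6-fold higher number from compound 2 to compound 3 (0.19 log units; within the scatter), lies within the scatter, whereas the step from the aromatic ring of compound 1, a 5.9-fold lower number from compound 1 to compound 3 (0.77 log units; beyond the scatter), lies beyond it. Compound 4 `O=C(O)c1ccccc1-c1ccc(CCc2ncc(Cc3cccc(F)c3F)[nH]2)cc1` differs from compound 3 by 2,3-difluorophenyl in place of cyclopropyl on a saturated chain carbon bound to an aromatic carbon. Within the data shown here, the step that bears on this change is the reverse of the one that produced compound 3, namely a 5.9-fold lower number from compound 1 to compound 3 (0.77 log units; beyond the scatter), which replaced an aromatic ring with cyclopropyl and lowered the number modestly. Because that step was a 5.9-fold lower number from compound 1 to compound 3 (0.77 log units; beyond the scatter), a return to an aromatic ring is expected to raise the number, though 2,3-difluorophenyl is not 4-cyanophenyl, so the rise is expected to be smaller. Compound 4 is therefore estimated at 2500 nM, with a range from 800 nM to 8000 nM, an expected step of a 2.5-fold higher number from compound 3 to compound 4 (0.40 log units; beyond the scatter).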

Compound 4, half-maximal effective concentration: 87 nM
The estimate for compound 4 lay 29-fold (1.46 log units) above the measured number; the whole stated range lies above it.
By their numbers in this assay, from the lowest: compound 4; then compounds 2 and 3 (each within the scatter of the next); then compound 1.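

In this assay, an aromatic ring on a saturated chain carbon bound to an aromatic carbon is not in itself unfavourable: 2,3-difluorophenyl in compound 4 gives the lowest number of the series, both against cyclopropyl (an 11-fold lower number from compound 3 to compound 4 (1.06 log units; beyond the scatter)) and against cyclohexylmethyl (a 7.4-fold lower number from compound 2 to compound 4 (0.87 log units; beyond the scatter)). The aromatic groups instead mark both ends of the series, as the change from 4-cyanophenyl shows (a 68-fold lower number from compound 1 to compound 4 (1.83 log units; beyond the scatter)). Nothing available explains this gap between the two aromatic groups. As far as these compounds go, whether the two fluorines are needed stays open, as does how an unsubstituted phenyl, a methoxyphenyl or a pyridine ring would read at this place.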